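The compounds below may be only part of what the source reports. "The series", "measured", "known", "first", "only" and "open" are said of these compounds alone.

Measured so far in a physicochemical assay for solubility, with a stated time of 18 h, at pH 7.4; on this read-out higher numbers stand for higher solubility and lower numbers for lower solubility:
Compound 1, `CC(C)Cc1ccc2c(NCCCNCc3ccco3)ccnc2c1`: 4200 nM
Compound 2, `COc1cccc(Oc2ccc3c(NCCCNCc4ccco4)ccnc3c2)c1`: 14500 nM
Compound 3, `COc1ccccc1Oc1ccc2c(NCCCNCc3ccco3)ccnc2c1`: 14500 nM

Compound 3 stands level with compound 2 at the digits given, the two together at the top of the three numbers; the lowest of the three is separated from the top by the step of a 3.5-fold higher number from compound 1 to compound 3 (0.54 log units; beyond the scatter). Compound 4, `c1coc(CNCCCNc2ccnc3cc(-c4cccc5ccccc45)ccc23)c1`, is not yet measured. The change is naphthalen-1-yl in place of 2-methoxyphenoxy on an aromatic carbon. Going by the values given here, the only step that bears on it is the one that brought the 2-methoxyphenoxy in, a 3.5-fold higher number from compound 1 to compound 3 (0.54 log units; beyond the scatter), and compound 4 now loses that group, with its two hydrogen-bond acceptors, for a group of carbon only. A modest fall is therefore expected, roughly back toward compound 1: the step of a 4.8-fold lower number from compound 3 to compound 4 (0.68 log units; beyond the scatter) is estimated, giving compound 4 an expected solubility of 3000 nM, within 900 nM to 9000 nM.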

Compound 4, solubility: 32000 nM
For compound 4 the middle estimate is 11-fold (1.03 log units) below the measured one; the measured number lies above the stated range.
By their numbers in this assay, from the lowest: compound 1; then compounds 2 and 3 (each within the scatter of the next); then compound 4.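

On this aromatic carbon, in this assay, naphthalen-1-yl, a group of carbon only with 0 hydrogen-bond acceptors, gives a higher number than either methoxyphenoxy group, with a 2.2-fold higher number from compound 3 to compound 4 (0.34 log units; beyond the scatter) and a 2.2-fold higher number from compound 2 to compound 4 (0.34 log units; beyond the scatter) as the steps. Across these compounds, then, a high number does not depend on the hydrogen-bond acceptors of those groups, and a 7.6-fold higher number from compound 1 to compound 4 (0.88 log units; beyond the scatter) sets naphthalen-1-yl well above isobutyl too. Nothing measured here explains this order.

As far as these compounds go, how an amine or a carboxylic acid on this same carbon would compare with naphthalen-1-yl remains open.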